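Pentyl in place of 4-methylpiperidin-1-yl: outlook for compound 3

The source may report more compounds than this note shows. Statements on the series, on what has been measured and on what is new or still open speak of the compounds shown alone.

compound 1 `CC(C(=O)NCc1ccc(C(C)(C)C)nc1SCCCN(C)C)c1ccc(NS(C)(=O)=O)c(F)c1`: 51.8 nM
compound 2 `CC1CCN(c2cc(C(C)(C)C)ccc2CNC(=O)C(C)c2ccc(NS(C)(=O)=O)c(F)c2)CC1`: 0.7 nM

In an assay on cells for antagonist activity at transient receptor potential cation channel subfamily V member 1 (Homo sapiens), read by FLIPR and calcium flux, with a stated time of 6 min (a lower number here means a stronger inhibitor, a higher number a weaker inhibitor), compound 2 gives 0.7 nM, the lowest of the two numbers; compound 1 gives 51.8 nM, a higher number beyond the scatter. Compound 3 `CCCCCc1cc(C(C)(C)C)ccc1CNC(=O)C(C)c1ccc(NS(C)(=O)=O)c(F)c1` differs from compound 2 in one place: pentyl in place of 4-methylpiperidin-1-yl on an aromatic carbon. Among the compounds with values here, no pair of measured compounds isolates this change, so its effect rests on expectation only. A modest weakening is expected, near the edge of the scatter; the expected step is a 2.9-fold higher number from compound 2 to compound 3 (0.46 log units; beyond the scatter). Compound 3 is expected to give 2 nM, with a range of 0.5 nM to 10 nM.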

Compound 3, inhibition constant: 2.8 nM
Compound 3: the middle estimate sits 1.4-fold (0.15 log units) below what was measured; measured number inside the range.
By their numbers in this assay, from the lowest: compound 2; then compound 3; then compound 1.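

In this assay, pentyl in place of 4-methylpiperidin-1-yl gives a 4.0-fold higher number from compound 2 to compound 3 (0.60 log units; beyond the scatter) and is a modest step. At this position, ortho to a large group, a low number therefore does not depend on a ring or a hydrogen-bond acceptor in the substituent, since compound 3 stays at 2.8 nM with neither. Nothing at hand accounts for the size of the step.

Open, on these data alone, is how the number responds to chain length, as with propyl or heptyl. Also open, as far as these compounds go, is whether a pentyl chain ending in a primary amine or a hydroxyl group keeps this level.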